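Adding isopropyl to the ring nitrogen of compound 2

This account rests on a few compounds, and the source may have more. Where it says the series, first, only, none or still open, it means among the compounds named here.

- compound 1 `CCOC(=O)C(=O)Nc1ccc(N(C)C)cc1C#N`: 2.4 mg/kg
- compound 2 `CCOC(=O)C(=O)Nc1cccc(NC)c1C#N`: 0.1 mg/kg
- compound 3 `CNc1cccc(NC(=O)C(=O)O)c1C#N`: 0.07 mg/kg

In a functional assay on the whole organism with Rattus norvegicus as the target (a lower number here means that less compound is needed, a higher number that more compound is needed for the effect), compound 2 gives 0.1 mg/kg. This value lies within the scatter of compound 3 at 0.07 mg/kg, and both stand well apart from compound 1 at 2.4 mg/kg.

The next compound, compound 4 `CCOC(=O)C(=O)Nc1cccc(N(C)C(C)C)c1C#N`, carries isopropyl in place of hydrogen on a nitrogen on an aromatic ring. For the measured compounds named here, only one measured step bears on the series, and it says little about this change. That step, a 1.4-fold lower number from compound 2 to compound 3 (0.15 log units; within the scatter), puts hydrogen in place of ethyl on an oxygen and leaves the nitrogen untouched. It shows that compound 2 and compound 3 cannot be told apart in this assay, but no measurement isolates a change on the nitrogen.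

Compound 1, at 2.4 mg/kg, shows only that a much higher number occurs among these compounds, and no single step links it to compound 2. A moderate rise is therefore expected, held with little confidence, and no change beyond the scatter remains possible. The expected move is a 3.0-fold higher number from compound 2 to compound 4 (0.48 log units; beyond the scatter). For compound 4 the estimate is 0.3 mg/kg, with an expected range of 0.08 mg/kg to 1.5 mg/kg.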

Compound 4, dose for half-maximal effect: 1.2 mg/kg
Estimate against measurement, compound 4: 4.0-fold (0.60 log units) below; the measured number falls inside the stated range.
By their numbers in this assay, from the lowest: compounds 3 and 2 (each within the scatter of the next); then compounds 4 and 1 (each within the scatter of the next).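

In this assay the nitrogen on the aromatic ring now has a measured step of its own: isopropyl in place of hydrogen gives a 12-fold higher number from compound 2 to compound 4 (1.08 log units; beyond the scatter) and so moves the number well beyond the scatter. For the compounds shown here, the only earlier step changed the group on the oxygen and stayed within the scatter, so this is the first measured sign that the number responds to a change at this nitrogen, with methylamino to isopropyl(methyl)amino raising the dose needed. No supporting measurement is available to explain the size of this step.

The compounds shown do not tell whether a group such as n-propyl or cyclopropyl on this nitrogen would give a similar rise. Nor do they tell whether a single added methyl in place of the isopropyl would give a smaller rise. They also leave open whether isopropyl on this nitrogen would have the same effect in a compound carrying the free acid of compound 3 rather than the ethyl ester.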